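Series notes: configuration switch from compound 2 to compound 3

The source may hold more compounds than are shown below. What is called first, only, known or untested is meant among the compounds shown, and "the series" means these compounds.

Two members of the series carry numbers. Compound 1 `COc1cc(/C=C/C(=O)/C=C(O)/C=C/c2ccc(OC(=O)[C@H](CC(C)C)NC(=O)OCc3ccccc3)c(OC)c2)ccc1OC(=O)[C@H](CC(C)C)NC(=O)OCc1ccccc1` gives 13% in a functional assay on the whole organism (strain Wistar) for inhibition, with Rattus norvegicus as the target, read by paw edema, with stated times of 1 h and 4 h, at a dose of 10 mg/kg by the intraperitoneal route; a lower number here means less inhibition, a higher number more inhibition at the dose given (going by the name of the read-out). Compound 2 `COc1cc(/C=C/C(=O)/C=C(O)/C=C/c2ccc(OC(=O)[C@H](C)NC(=O)OC(C)(C)C)c(OC)c2)ccc1OC(=O)[C@H](C)NC(=O)OC(C)(C)C` gives 32% in this assay, and this is the higher of the two numbers in hand; its distance from compound 1 lies beyond the usual scatter, so compound 2 stands above compound 1 on the evidence so far.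

Compound 3 `COc1cc(/C=C/C(=O)/C=C(O)/C=C/c2ccc(OC(=O)[C@@H](C)NC(=O)OC(C)(C)C)c(OC)c2)ccc1OC(=O)[C@@H](C)NC(=O)OC(C)(C)C` is not yet measured. It differs from compound 2 only as follows: the two compounds have the same atoms and bonds and differ only in configuration as drawn: 2 of 5 stereo elements differ; a stereocentre at a saturated chain carbon is drawn S in compound 2 and R in compound 3; a stereocentre at a saturated chain carbon is drawn S in compound 2 and R in compound 3. Both stereocentres are thus inverted together, and every other part of the structure is kept.

Among the compounds with values here, no pair of measured compounds differs only in configuration, so there is nothing in hand that tells how large such a step is or in which direction it runs. The expectation is therefore a step from compound 2 to compound 3 of no size beyond the scatter, with a slight lean downward, a number 5 percentage points lower from compound 2 to compound 3 (within the scatter), since the measured number of compound 2 sits at the top of the small set and a repeat would as likely land lower as higher.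

Compound 3 is estimated at 27% in this assay, within a range from 12% to 42%.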

Compound 3, a percentage reported as inhibition, in the whole organism at one dose (the size of the read-out at that dose, not a potency): 48%
Estimate against measurement, compound 3: 21 percentage points below; measured number outside the range, above it.
By their numbers in this assay, from the lowest: compound 1; then compound 2; then compound 3.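

Inverting both stereocentres at the saturated chain carbons from S to R gives a number 16 percentage points higher from compound 2 to compound 3 (beyond the scatter) in this assay, so in this series configuration at these two carbons can by itself move the read-out. Within the data shown here, this is the first step that can be read as a single kind of change, and it can be assigned to configuration because nothing else in the structure varies: the fact that compounds 2 and 3 differ only in the configuration as drawn. The read-out is taken at one dose, so the step shows more inhibition at that dose for the R form as drawn, and it is not a statement about potency.

Since the two stereocentres change together, the compounds shown leave open whether a single inversion, giving a compound drawn S at one centre and R at the other, would carry all, part or none of the step. Also open, from the compounds shown here alone, is whether the same inversion would run in the same direction with the side chain and carbamate of compound 1, or with a free amine in place of the carbamate.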